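Swapping chloro for nitro on the benzyl ether of compound 1

The compounds below may be only part of what the source reports. "The series", "measured", "known", "first", "only" and "open" are said of these compounds alone.

Compound 1 `N[C@]1(C(=O)O)[C@H]2[C@@H](C[C@H]1OCc1cccc(Cl)c1)[C@]2(F)C(=O)O` and compound 2 `N[C@]1(C(=O)O)[C@H]2[C@@H](C[C@H]1OCc1ccccc1-c1ccccc1)[C@]2(F)C(=O)O` share the same core and differ only in the group carried on the benzyl ether. In an assay on CHO cells for binding affinity to metabotropic glutamate receptor 2 (Rattus norvegicus) (a lower number here means a stronger inhibitor, a higher number a weaker inhibitor), compound 1 gives 3.28 nM, and compound 2 gives 4.07 nM. Compound 1 has the lowest of the two numbers, and the gap to compound 2 lies within the scatter, so the two cannot be told apart on this evidence.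

Compound 3 `N[C@]1(C(=O)O)[C@H]2[C@@H](C[C@H]1OCc1cccc([N+](=O)[O-])c1)[C@]2(F)C(=O)O` has not yet been measured in this assay. It is made from compound 1 by nitro in place of chloro on an aromatic carbon. Among the compounds with values here, no measured pair shows this particular swap, so nothing in the data fixes its size or direction. Within the data shown here, with only two closely similar numbers to go on, the expectation is a step from compound 1 to compound 3 of a 1.5-fold higher number from compound 1 to compound 3 (0.18 log units; within the scatter), within or close to the scatter. Compound 3 is therefore estimated at 5 nM, with a range from 1.5 nM to 20 nM.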

Compound 3, inhibition constant: 7.87 nM
For compound 3 the middle estimate is 1.6-fold (0.20 log units) below the measured one, within the range that was stated.
By their numbers in this assay, from the lowest: compounds 1, 2 and 3 (each within the scatter of the next, the first and the last beyond it).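

In this assay, within the data shown here, nitro in place of chloro on an aromatic carbon, meta to a large group, gives a 2.4-fold higher number from compound 1 to compound 3 (0.38 log units; beyond the scatter), the only step here that changes a single place. This shows that what sits at this position does affect the number, but only modestly: three heavy atoms with two hydrogen-bond acceptors replace a single chlorine, and compound 3 still gives 7.87 nM. Nothing measured here says what lies behind the step.

One swap at one position cannot show how far this tolerance extends. An amine, a carboxylic acid or a methoxy group on the same aromatic carbon would test whether other groups also stay close to compound 1 or move further from it.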